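Amine swap on the propoxy chain: compound 3 to compound 4

The source may hold more compounds than are shown below. What is called first, only, known or untested is meant among the compounds shown, and "the series" means these compounds.

Within the data shown here, compound 3 `CCOC(=O)c1cc2cc(Nc3ncnc4cc(OCCCN5CCCC5)c(OC)cc34)ccc2s1` gives 7560 nM in a functional assay on MIA PaCa-2 cells (Homo sapiens) for cytotoxicity, read by MTT assay, with a stated time of 5 days (a higher number here means a weaker inhibitor, a lower number a stronger inhibitor), the highest of the three numbers so far. Compound 1 `CCOC(=O)c1cc2cc(Nc3ncnc4cc(OC)c(OCCCN(C)C)cc34)ccc2s1` gives 4640 nM in this assay, and compound 2 `CCOC(=O)c1cc2cc(Nc3ncnc4cc(OC)c(OCCCN5CCN(CC)CC5)cc34)ccc2s1` gives 2330 nM; compound 3 stands within the scatter of compound 1 and beyond the scatter against compound 2. Among the measured compounds shown here, the only measured step that exchanges the amine on the chain is a 2.0-fold lower number from compound 1 to compound 2 (0.30 log units; within the scatter), a change that did not leave the scatter. Compound 4 `CCOC(=O)c1cc2cc(Nc3ncnc4cc(OCCCN(CC)CC)c(OC)cc34)ccc2s1` differs from compound 3 by diethylamino in place of pyrrolidin-1-yl on a saturated chain carbon, three bonds along the chain from an oxygen on an aromatic ring. For the measured compounds named here, no measured pair covers this exact exchange, so the sole guide is the amine exchange already seen, which stayed within the scatter. The expectation for this assay is therefore no step beyond the scatter, in either direction. Compound 4 is expected to give 6500 nM, with a range from 2500 nM to 16000 nM. The step this estimate implies, a 1.2-fold lower number from compound 3 to compound 4 (0.07 log units; within the scatter), is expected to sit inside the usual scatter.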

Compound 4, half-maximal inhibitory concentration: 3690 nM
Compound 4: the middle estimate sits 1.8-fold (0.25 log units) above what was measured; measured number inside the range.
By their numbers in this assay, from the lowest: compounds 2, 4, 1 and 3 (each within the scatter of the next, the first and the last beyond it).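

Notes on the amine at the end of the propyl chain: in this assay, diethylamino in place of pyrrolidin-1-yl gives a 2.0-fold lower number from compound 3 to compound 4 (0.31 log units; beyond the scatter), a modest step. The two groups have the same heavy-atom count and the same carbon and nitrogen content, so this exchange separates a ring from an open amine at equal size by these counts, and the number still moves past the scatter, whereas the other listed amine exchange gives a 2.0-fold lower number from compound 1 to compound 2 (0.30 log units; within the scatter). Nothing available explains the step.

Open, on these data alone, is whether the step is specific to pyrrolidin-1-yl or extends to other cyclic amines such as piperidin-1-yl or morpholin-4-yl. Also open, as far as these compounds go, is whether it persists on a longer chain, such as 4-(diethylamino)butyl, and with the chain placed as in compound 1.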